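The source may hold more compounds than are shown below. What is called first, only, known or untested is meant among the compounds shown, and "the series" means these compounds.

Measured compounds:
- compound 1, `Cc1nc(N)c2nc(-c3ccccc3)sc2n1`, 2660 nM
- compound 2, `Nc1nc(-c2cccc(CO)c2)nc2sc(-c3ccccc3)nc12`, 3.7 nM
- compound 3, `COc1ccc(-c2nc(N)c3nc(-c4ccccc4)sc3n2)cc1`, 46.7 nM

In an assay on CHO cells for displacement of a labelled ligand from adenosine receptor A3 (Homo sapiens), read by scintillation counting, with a stated time of 3 h (on this read-out lower numbers stand for stronger inhibition and higher numbers for weaker inhibition), compound 2 gives the lowest number of the three. Its nearest neighbour is compound 3, reached by a 13-fold higher number from compound 2 to compound 3 (1.10 log units; beyond the scatter), and the furthest is compound 1, as a 720-fold lower number from compound 1 to compound 2 (2.86 log units; beyond the scatter) shows. Compound 4, `Cc1ccc(-c2nc(N)c3nc(-c4ccccc4)sc3n2)o1`, has not yet been measured; it differs from compound 2 by 5-methylfuran-2-yl in place of 3-(hydroxymethyl)phenyl on an aromatic carbon. Within the data shown here, two measured steps bear on this change. Both a 720-fold lower number from compound 1 to compound 2 (2.86 log units; beyond the scatter) and a 57-fold lower number from compound 1 to compound 3 (1.76 log units; beyond the scatter) show that an aromatic ring on this carbon, in place of methyl, lowers the number strongly, while a 13-fold higher number from compound 2 to compound 3 (1.10 log units; beyond the scatter) shows that which ring it is matters as well. Since 5-methylfuran-2-yl is a ring, though a different one from 3-(hydroxymethyl)phenyl and lacking the hydrogen-bond donor counted above, compound 4 is expected to stay far from compound 1 but to give a higher number than compound 2. The expected step is an 8.1-fold higher number from compound 2 to compound 4 (0.91 log units; beyond the scatter). Compound 4 is therefore estimated at 30 nM, within a range of 8 nM to 150 nM.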

Compound 4, inhibition constant: 24.9 nM
Compound 4: the middle estimate sits 1.2-fold (0.08 log units) above what was measured, within the range that was stated.
By their numbers in this assay, from the lowest: compound 2; then compounds 4 and 3 (each within the scatter of the next); then compound 1.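

In this assay the gain over methyl does not depend on a six-membered ring of carbon only, since 5-methylfuran-2-yl, a five-membered aromatic ring with one hetero atom, also gives a 110-fold lower number from compound 1 to compound 4 (2.03 log units; beyond the scatter) on the same carbon. The choice of ring still counts, as a 6.7-fold higher number from compound 2 to compound 4 (0.83 log units; beyond the scatter) keeps 3-(hydroxymethyl)phenyl apart from the furan, whereas a 1.9-fold lower number from compound 3 to compound 4 (0.27 log units; within the scatter) leaves the furan and 4-methoxyphenyl unresolved at this position. Nothing shown here accounts for these differences.

The compounds shown leave open whether a saturated ring such as piperidine or an open chain such as n-butyl would keep the gain over methyl. They also leave open what the methyl of the furan contributes, and whether a hydroxymethyl group or a carboxylic acid on the furan would bring the number closer to that of compound 2.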